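Adding a bromo group to compound 2

The compounds below may be only part of what the source reports. "The series", "measured", "known", "first", "only" and "open" are said of these compounds alone.

Compound 1 `Cn1ccc2c(Oc3ccc(NC(=O)c4cc5cccnc5n(-c5ccccc5)c4=O)cc3)ncnc21` gives 88400 nM
Compound 2 `Cn1ccc2c(Oc3ccc(NC(=O)c4cc5cccnc5n(-c5ccccc5)c4=O)cc3F)ncnc21` gives 73400 nM

For the measured compounds named here, in a functional assay on MCF7 cells (Homo sapiens) for cytotoxicity, read by MTT assay, with a stated time of 72 h (a lower number here means a stronger inhibitor, a higher number a weaker inhibitor), compound 2 gives 73400 nM and lies within the scatter of the only other measured compound, compound 1 at 88400 nM, so neither ranks ahead. Compound 3 `Cn1ccc2c(Oc3ccc(NC(=O)c4cc5cccnc5n(-c5ccc(Br)cc5)c4=O)cc3F)ncnc21` differs from compound 2 in one place: bromo in place of hydrogen on an aromatic carbon. In words, this is bromo in place of hydrogen on an aromatic carbon, which turns phenyl to 4-bromophenyl. Going by the values given here, only one measured step bears on it, a 1.2-fold lower number from compound 1 to compound 2 (0.08 log units; within the scatter). That step also puts a halogen on an aromatic carbon, but as fluoro on a different ring, and it stays within the scatter. Among the compounds with values here, no measurement yet tests a change on the phenyl group, so the guidance is weak, and in this assay no step beyond the scatter is expected. The expected step is a 1.2-fold lower number from compound 2 to compound 3 (0.09 log units; within the scatter), with no firm direction. For compound 3 the estimated value is 60000 nM, within an expected range of 20000 nM to 130000 nM.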

Compound 3, half-maximal inhibitory concentration: 59400 nM
Beside the measured number, compound 3's estimate is 1.0-fold (0.00 log units) above it, within the range that was stated.
By their numbers in this assay, from the lowest: compounds 3, 2 and 1 (each within the scatter of the next).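

In this assay, the only step shown at the phenyl group, phenyl to 4-bromophenyl, gives a 1.2-fold lower number from compound 2 to compound 3 (0.09 log units; within the scatter). A bromo group on this six-membered aromatic ring, para to a large group, therefore leaves the number within the scatter, just as the fluoro step on a different ring did, with a 1.2-fold lower number from compound 1 to compound 2 (0.08 log units; within the scatter). Nothing measured here offers an explanation for this result.

From the compounds shown here alone, whether an amine, a carboxylic acid or a methoxy group in the same place on the phenyl group would give a step beyond the scatter remains open, as does the outcome of bromo elsewhere on that ring. Since each step shown stays within the scatter, these compounds do not reveal which part of the structure, if any, governs cytotoxicity on these cells.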